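Urea to Amide: Predicting Compound 3 in a Pyrazole Series

The compounds below may be only part of what the source reports. "The series", "measured", "known", "first", "only" and "open" are said of these compounds alone.

Compound 1 `COc1cc(-c2nn(-c3ccc(NC(=O)Nc4ccc(Cl)c(Cl)c4)cc3)cc2-c2ccncc2)ccc1Cl`: 3440 nM
Compound 2 `COc1cc(-c2nn(-c3ccc(NC(=O)Nc4ccc(Cl)c(C(F)(F)F)c4)cc3)cc2-c2ccncc2)ccc1Cl`: 1630 nM

Among the measured compounds shown here, in a functional assay on SK-MEL-2 cells (Homo sapiens) for antiproliferative activity, read by sulforhodamine B assay, with a stated time of 48 h (a lower number here means a stronger inhibitor, a higher number a weaker inhibitor), compound 2 gives the lowest of the two numbers so far; compound 1 sits a step above it, as the change a 2.1-fold lower number from compound 1 to compound 2 (0.32 log units; beyond the scatter) shows. Compound 3 `COc1cc(-c2nn(-c3ccc(NC(=O)c4ccc(Cl)c(Cl)c4)cc3)cc2-c2ccncc2)ccc1Cl` carries the change (3,4-dichlorophenyl in place of (4-chloro-3-(trifluoromethyl)phenyl)amino on a carbonyl carbon). This both returns to the two chlorines of compound 1 and removes one amide-type nitrogen from the linker. For the measured compounds named here, the chloro-to-trifluoromethyl step is the only measured one that bears on it, and no measured step covers the loss of the nitrogen. A modest rise is therefore expected, a 2.8-fold higher number from compound 2 to compound 3 (0.44 log units; beyond the scatter), with compound 3 estimated at 4500 nM (range 1500 nM to 14000 nM).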

Compound 3, half-maximal inhibitory concentration: 5740 nM
Compound 3: middle estimate off by 1.3-fold (0.11 log units), on the low side; measured number inside the range.
By their numbers in this assay, from the lowest: compound 2; then compounds 1 and 3 (each within the scatter of the next).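

In this assay, the two dichloro compounds that differ only by the linker nitrogen and its hydrogen cannot be told apart (a 1.7-fold higher number from compound 1 to compound 3 (0.22 log units; within the scatter)), so in this pair that nitrogen shows no measurable part. The larger step (a 3.5-fold higher number from compound 2 to compound 3 (0.55 log units; beyond the scatter)) lies beyond the scatter, but it changes the ring substituent and the linker together. No measurement here gives a reason for either step. Still open, as far as these compounds go, is whether 4-chloro-3-(trifluoromethyl)phenyl on the carbonyl carbon would match compound 2, and how a methylene in place of the lost nitrogen would read.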